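Taking the Nitrile Off Compound 2

A few compounds are considered here, and "the series" means these few. Any claim that something is new, unique, unknown or untested is made for them only; others in the source may bear on it.

In a functional assay on A549 cells (Homo sapiens) for cytotoxicity, read by MTT assay, with a stated time of 72 h (a lower number here means a stronger inhibitor, a higher number a weaker inhibitor), compound 1 (`CNC(=O)c1cc(Oc2ccc(C(=O)/C=C/c3ccco3)cc2)ccn1`) stands at "not determined" (no result reported). Compound 2 (`CNC(=O)c1cc(Oc2ccc(C(=O)/C=C/c3ccc(C#N)cc3)cc2)ccn1`) gives 26400 nM. For the measured compounds named here, that is the only number available, so compound 2 cannot yet be ranked as strong or weak against a relative. Compound 3 (`CNC(=O)c1cc(Oc2ccc(C(=O)/C=C/c3ccccc3)cc2)ccn1`) has not been measured. It differs from compound 2 in a single place: hydrogen in place of cyano on an aromatic carbon. Put simply, hydrogen takes the place of cyano on an aromatic carbon, which turns 4-cyanophenyl into phenyl. Going by the values given here, no measured pair shows what this swap does in this assay, so the data offer no direction to follow. The estimated step, a 1.3-fold lower number from compound 2 to compound 3 (0.12 log units; within the scatter), stays within the usual scatter, so no real change either way is expected. The expected value for compound 3 is 20000 nM, with a likely range of 7000 nM to 55000 nM.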

Compound 3, half-maximal inhibitory concentration: 5040 nM
Estimate against measurement, compound 3: 4.0-fold (0.60 log units) above; measured number outside the range, below it.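

Replacing cyano with hydrogen on this aromatic carbon gives a 5.2-fold lower number from compound 2 to compound 3 (0.72 log units; beyond the scatter) in this assay, the first sign that this position responds to what sits on it. Within this pair, the nitrile is not needed for activity, and the plain phenyl of compound 3 is the stronger inhibitor. Nothing available explains this shift.

A single pair cannot show whether hydrogen is the best choice here or whether any group on this carbon would weaken the compound, a question that an amine, a methoxy group or a chlorine atom at the same place could help to settle. Comparisons with compound 1 cannot be read, so the effect of changing the whole aromatic ring stays open.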